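The source may hold more compounds than are shown below. What is called first, only, known or untested is meant among the compounds shown, and "the series" means these compounds.

Measured compounds:
- compound 1 `C#CCNC1CCc2c(SCCc3cccc(C)c3)cccc21`: 4960 nM
- compound 2 `C#CCNC1CCc2c(SCc3cccc(F)c3)cccc21`: 11600 nM
- compound 3 `C#CCNC1CCc2c(SCCc3cccc(C(F)(F)F)c3)cccc21`: 280 nM

In an ADME assay on isolated protein for inhibition of Amine oxidase [flavin-containing] B (Homo sapiens) (a higher number here means a weaker inhibitor, a lower number a stronger inhibitor), compound 1 gives 4960 nM, the second highest of the three numbers; compound 2 sits nearer to it with 11600 nM, while compound 3 with 280 nM lies much further away. Compound 4 `C#CCNC1CCc2c(SCCc3ccc(Cl)cc3)cccc21` differs from compound 1 in one place: 4-chlorophenyl in place of 3-methylphenyl on a saturated chain carbon, two bonds along the chain from a sulfur. Among the measured compounds shown here, only one measured step bears on this change, an 18-fold lower number from compound 1 to compound 3 (1.25 log units; beyond the scatter), where the methyl of compound 1 gave way to a trifluoromethyl on the same ring. Compound 2 differs from compound 1 in more than one place, so its value shows only that a shorter chain with a fluorophenyl gives a somewhat higher number. With a halogen entering in place of the methyl, though at a different ring position and as a single chlorine rather than a trifluoromethyl, a lower number is expected for compound 4, though a smaller step than from compound 1 to compound 3. The step expected for compound 4 is a 3.3-fold lower number from compound 1 to compound 4 (0.52 log units; beyond the scatter). Compound 4 is therefore estimated at 1500 nM, with a range from 400 nM to 5500 nM.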

Compound 4, half-maximal inhibitory concentration: 920 nM
Beside the measured number, compound 4's estimate is 1.6-fold (0.21 log units) above it; measured number inside the range.
By their numbers in this assay, from the lowest: compound 3; then compound 4; then compound 1; then compound 2.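

In this assay, 4-chlorophenyl in place of 3-methylphenyl on the saturated chain carbon gives a 5.4-fold lower number from compound 1 to compound 4 (0.73 log units; beyond the scatter) and so shows that a lower number at this end of the chain is not tied to the trifluoromethyl replacement behind an 18-fold lower number from compound 1 to compound 3 (1.25 log units; beyond the scatter) alone. Here, however, the substituent and its place on the ring change together, so this step cannot say which of the two accounts for the drop. No measurement at hand explains the step from compound 1 to compound 4.

A chlorine at the ring position held by the methyl of compound 1, or a methyl at the position held by the chlorine of compound 4, would separate those two changes. Going by these compounds, how a methoxy group or an amine on this ring, or a longer chain, would read in this assay remains open.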